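The source may report more compounds than this note shows. Statements on the series, on what has been measured and on what is new or still open speak of the compounds shown alone.

Measured so far in a functional assay on HeLa cells (Homo sapiens) for inhibition, with a stated time of 72 h; on this read-out lower numbers stand for stronger inhibition and higher numbers for weaker inhibition:
- compound 1 `CC(C)(O)CNc1nc(NCc2ccc(-c3ccco3)cc2)c2ncn(C3CCCC3)c2n1`: 14800 nM
- compound 2 `NC1CCC(Nc2nc(NCc3ccc(-c4ccco4)nc3)c3ncn(C4CCCC4)c3n2)CC1`: 30 nM
- compound 3 `OC1CCC(Nc2nc(NCc3ccc(-c4ccco4)nc3)c3ncn(C4CCCC4)c3n2)CC1`: 247 nM

Among these three numbers, compound 3 at 247 nM is the second highest, with compound 2 lower and compound 1 higher. The next compound, compound 4 `CC(C)(O)CNc1nc(NCc2ccc(-c3ccco3)nc2)c2ncn(C3CCCC3)c2n1`, differs from compound 3 only in the group on the nitrogen: 2-hydroxy-2-methylpropyl in place of 4-hydroxycyclohexyl on a nitrogen on an aromatic ring.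

Within the data shown here, no measured step covers this exchange itself. Among the measured compounds shown here, the one measured step at the same substituent, an 8.2-fold higher number from compound 2 to compound 3 (0.92 log units; beyond the scatter), is a smaller edit, hydroxy in place of amino on a saturated ring carbon, and it lies beyond the scatter. Compound 1 carries the same 2-hydroxy-2-methylpropyl group as compound 4 but differs from it elsewhere in the structure, so compound 1 at 14800 nM can only be a loose guide. It is nevertheless the highest number seen, and it points towards weaker inhibition. A move to a higher number in this assay is therefore expected, larger than the measured step but short of the full gap up to compound 1. The expected change is a 10-fold higher number from compound 3 to compound 4 (1.01 log units; beyond the scatter). The estimate for compound 4 is 2500 nM, with an expected range from 600 nM to 10000 nM.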

Compound 4, half-maximal inhibitory concentration: 667 nM
Compound 4: the middle estimate sits 3.7-fold (0.57 log units) above what was measured; the measured number falls inside the stated range.
By their numbers in this assay, from the lowest: compound 2; then compound 3; then compound 4; then compound 1.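

In this assay, replacing the 4-hydroxycyclohexyl ring with the open 2-hydroxy-2-methylpropyl chain gives only a 2.7-fold higher number from compound 3 to compound 4 (0.43 log units; beyond the scatter), so activity on this nitrogen does not depend on that ring, yet the same chain compares much less well with 4-aminocyclohexyl, at a 22-fold higher number from compound 2 to compound 4 (1.35 log units; beyond the scatter). With 2-hydroxy-2-methylpropyl held constant, the change to 6-(furan-2-yl)pyridin-3-yl from 4-(furan-2-yl)phenyl gives a 22-fold lower number from compound 1 to compound 4 (1.35 log units; beyond the scatter), so the high number of compound 1 cannot be attributed to the chain alone: among the compounds with this chain, it goes with the 4-(furan-2-yl)phenyl group. No measurement is available here to explain either shift.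

The compounds shown leave open whether an open chain ending in an amine, such as 2-amino-2-methylpropyl, would bring the number close to that of compound 2, or whether the amino group's advantage is confined to the cyclohexyl ring. They also leave open how a shorter chain such as 2-hydroxyethyl would behave on this nitrogen, and whether 4-aminocyclohexyl would give a comparably low number alongside 4-(furan-2-yl)phenyl.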